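Sulfonyl aryl swaps held at the cytotoxicity ceiling

This account rests on a few compounds, and the source may have more. Where it says the series, first, only, none or still open, it means among the compounds named here.

Three compounds were tested in an ADME assay on HEK293 cells (Homo sapiens) for cytotoxicity, read by resazurin assay, with a stated time of 48 h; on this read-out higher numbers stand for lower toxicity in this test and lower numbers for higher toxicity in this test:
compound 1 `O=S(=O)(Nc1ccc(-c2nc3ccccc3o2)cc1)c1cccs1`: > 100000 nM
compound 2 `COc1ccc(Cl)cc1S(=O)(=O)Nc1ccc(-c2nc3ccccc3o2)cc1`: 75000 nM
compound 3 `O=S(=O)(Nc1ccc(-c2nc3ccccc3o2)cc1)c1ccccc1Cl`: > 100000 nM

Compound 3 reports only a limit of this assay, > 100000 nM. Compound 1 likewise sits at a limit, > 100000 nM. Compound 2 gives a number, 75000 nM. Thus compound 3 stands at the limit of > 100000 nM in this assay, at which 2 of the 3 values shown sit, alongside compound 1, with compound 2 the one measured value close by. The steps of an at least 1.3-fold lower number from compound 1 to compound 2 (0.12 log units; that floor lies within the scatter) and an at least 1.3-fold higher number from compound 2 to compound 3 (0.12 log units; that floor lies within the scatter) stayed within the scatter, and a step that the two limits leave unreadable from compound 1 to compound 3. Compound 4 `O=S(=O)(Nc1ccc(-c2nc3ccccc3o2)cc1)c1cccc(F)c1` differs from compound 3 by 3-fluorophenyl in place of 2-chlorophenyl on a sulfonyl sulfur. As every aryl swap on the sulfonyl sulfur so far gave an at least 1.3-fold lower number from compound 1 to compound 2 (0.12 log units; that floor lies within the scatter) or an at least 1.3-fold higher number from compound 2 to compound 3 (0.12 log units; that floor lies within the scatter), no step beyond the scatter is expected. The estimate amounts to a number no higher from compound 3 to compound 4 (the limit leaves the size open). Compound 4 is estimated at 100000 nM, within 50000 nM to 200000 nM.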

Compound 4, half-maximal cytotoxic concentration: > 100000 nM
Compound 4: no number, only a limit; the forecaster's own chance of this, stated with the estimate: 60%; the middle value lies on the limit itself.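

Among these compounds, with 3-fluorophenyl on the sulfonyl sulfur, a fluorine enters this position for the first time, and in this assay compound 4 still gives only a limit of the assay, not a number: the limit of > 100000 nM in this assay, at which 3 of the 4 values shown sit. Among the compounds shown here, the one readable step, an at least 1.3-fold higher number from compound 2 to compound 4 (0.12 log units; that floor lies within the scatter), stays within the scatter, and the steps to the two other compounds at the limit cannot be read. From the compounds shown here alone, how far compound 1, compound 3 and compound 4 lie past that limit stays open, as does whether an amine or a carboxylic acid at this position would give a measurable number.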